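What losing one methoxy group may do

A few compounds are considered here, and "the series" means these few. Any claim that something is new, unique, unknown or untested is made for them only; others in the source may bear on it.

Compound 1 (`COc1cc(CC[C@@H](O)C[C@H](O)CCc2ccc(O)cc2)ccc1O`) gives "not determined" (no result reported)
Compound 2 (`OC[C@H]1O[C@@H](O[C@H](CCc2ccc(O)c(O)c2)C[C@H](O)CCc2ccc(O)c(O)c2)[C@H](O)[C@@H](O)[C@@H]1O`) gives 92 ug/mL

Both compounds were examined in a functional assay on HSC-2 cells (Homo sapiens) for cytotoxicity, read by MTT assay (on this read-out higher numbers stand for weaker inhibition and lower numbers for stronger inhibition), but only compound 2 has a number there. Compound 1 therefore has no place on this scale and offers no starting value. Compound 3 (`Oc1ccc(CC[C@@H](O)C[C@H](O)CCc2ccc(O)cc2)cc1`) keeps the core of compound 1 and differs from it by a single swap (hydrogen in place of methoxy on an aromatic carbon): hydrogen in place of methoxy on an aromatic carbon, ortho to a hydroxy group. For the measured compounds named here, no measured pair shows what this swap does in this assay so the data give no size or direction for the step, and none beyond the scatter is expected. Going by the values given here, the only nearby number belongs to compound 2 at 92 ug/mL so compound 3 is expected to fall in the same broad region. Compound 3 is estimated at 70 ug/mL (expected range 25 ug/mL to 200 ug/mL).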

Compound 3, half-maximal inhibitory concentration: 231 ug/mL
Compound 3: middle estimate off by 3.3-fold (0.52 log units), on the low side; measured number outside the range, above it.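

For the compounds shown here, compound 3 now has a number, but compound 1 has none in this assay so no step between compound 1 and compound 3 can be read. On these data alone, what putting hydrogen in place of methoxy does here stays open, and no further data bear on this result.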